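The compounds below may be only part of what the source reports. "The series", "measured", "known", "first", "only" and "open" are said of these compounds alone.

Of the compounds shown here, two with the same core have been measured in a functional assay on MKN-74 cells (Homo sapiens) for antiproliferative activity, with a stated time of 24 h; a higher number here means a weaker inhibitor, a lower number a stronger inhibitor. Compound 1 `Cc1ccccc1NC(=S)N1CCc2c(sc(NC(=O)c3ccccc3Br)c2C(N)=O)C1` gives in this assay a value of > 50000 nM, which is a limit of the assay and not a number. Compound 2 `Cc1ccccc1C(=O)Nc1sc2c(c1C(N)=O)CCN(C(=S)Nc1ccccc1C(F)(F)F)C2` gives in this assay 17400 nM, the only number shown. The evidence on where the values sit amounts to the limit of > 50000 nM in this assay, at which 1 of the 2 values shown sits. Compound 3 `Cc1ccccc1NC(=S)N1CCc2c(sc(NC(=O)c3ccccc3C)c2C(N)=O)C1` has not yet been measured in this assay. It differs from compound 2 by one change, (methyl in place of trifluoromethyl on an aromatic carbon), on an aromatic carbon of a six-membered aromatic ring of carbon only, ortho to a large group. Going by the values given here, no measured pair shows a step of this kind, so the expectation rests on compound 2 alone, and a small step toward a weaker inhibitor is expected, a 1.4-fold higher number from compound 2 to compound 3 (0.16 log units; within the scatter). Compound 3 is estimated to give 25000 nM in this assay, with a range from 10000 nM to 60000 nM.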

Compound 3, half-maximal inhibitory concentration: > 50000 nM
Compound 3 ended at the assay's limit; the forecaster's own chance of this, stated with the estimate: 35%; at least 2.0-fold (0.30 log units) between middle value and limit.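

In this assay, going by these compounds alone, placing methyl where trifluoromethyl stood on this aromatic carbon gives an at least 2.8-fold higher number from compound 2 to compound 3 (0.45 log units; beyond the scatter), the first readable step and one beyond the usual scatter. This position therefore responds to the group it carries: in this one pair, trifluoromethyl goes with a measurable value, while methyl does not. The change from bromo to methyl that links compound 1 and compound 3 cannot be read, and the series now rests mostly on one limit: the limit of > 50000 nM in this assay, at which 2 of the 3 values shown sit.

On these data alone, compound 3 holds a limit and not a number, so the full size of the step stays open. Also open, as far as these compounds go, is how a chlorine atom, a methoxy group or an amine on this same aromatic carbon would fare, and whether trifluoromethyl here would keep a measurable value alongside the bromo group of compound 1.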